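The compounds below may be only part of what the source reports. "The series", "measured", "known", "first", "only" and "open" are said of these compounds alone.

Working notes on the series, read in a functional assay on cells (Platelet, Homo sapiens) for inhibition; on this read-out higher numbers stand for weaker inhibition and lower numbers for stronger inhibition. Compound 1 `CCOC(=O)c1ccc(-c2nn(Cc3ccccc3Cl)c3ccccc23)cc1` gives > 10000 nM, which is a limit and not a number. Compound 2 `CCOC(=O)c1ccc(-c2nn(C(C)C)c3ccccc23)cc1` gives > 10000 nM, which is also a limit. Among the compounds with values here, compound 2 therefore has no numeric value, and the only other value beside it is a limit too: the limit of > 10000 nM in this assay, at which 2 of the 2 values shown sit. Within the data shown here, the one measured change on this nitrogen is a step that the two limits leave unreadable from compound 1 to compound 2, so no size can be taken from it.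

Compound 3 `CCCCn1nc(-c2ccc(C(=O)OCC)cc2)c2ccccc21` has butyl in place of isopropyl on an aromatic nitrogen. Among the measured compounds shown here, no measured step gives a size for this change, and no shift in either direction can be predicted from the data. Compound 3 is expected to remain in the same region of this assay because of the limit of > 10000 nM in this assay, at which 2 of the 2 values shown sit. The estimated step is a step that the limit leaves unreadable from compound 2 to compound 3. For compound 3 the expected value is 12000 nM, with an estimated range of 4000 nM to 40000 nM.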

Compound 3, half-maximal inhibitory concentration: > 10000 nM
Compound 3: a limit, no number; the forecaster's own chance of this, stated with the estimate: 85%; the middle value does not contradict the limit.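

Compound 1, compound 2 and compound 3 all sit at a limit and not at a number, so no step among them can be read: the limit of > 10000 nM in this assay, at which 3 of the 3 values shown sit.

The compounds shown leave open whether any group on this aromatic nitrogen gives a numeric value in this assay.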